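This account rests on a few compounds, and the source may have more. Where it says the series, first, only, none or still open, it means among the compounds named here.

Measured so far:
compound 1, `CCN(CC)CCCC(C)/N=C(/N)NC(=O)c1cccc(Cl)c1CCc1cc(Br)ccc1OC` — 260 nM
compound 2, `COc1ccc(Br)cc1CCc1c(F)cccc1C(=O)/N=C(\N)NCCN1CCCC1` — 4500 nM
compound 3, `CCN(CC)CCCC(C)/N=C(/N)NC(=O)c1cccc(F)c1CCc1ccc2ccccc2c1` — 1800 nM

In a functional assay for antagonist activity at Melanocortin receptor 4 (Homo sapiens), read by cAMP accumulation (on this read-out higher numbers stand for weaker inhibition and lower numbers for stronger inhibition), compound 2 gives the highest of the three numbers, beyond the scatter from compound 3 and far beyond the scatter from compound 1. Compound 4, `COc1ccc(Br)cc1CCc1c(F)cccc1C(=O)/N=C(\N)NCCCN1CCCCC1`, is not yet measured. It differs from compound 2 by (piperidin-1-yl)methyl in place of pyrrolidin-1-yl on a saturated chain carbon, two bonds along the chain from an amine nitrogen, so the basic amine sits one carbon further from the amidine and carries a larger ring. Compounds 1 and 3, which both carry a longer chain to their amine, give the two lower numbers, though they also differ elsewhere. A modest gain, the step from compound 2 to compound 4 estimated as a 3.0-fold lower number from compound 2 to compound 4 (0.48 log units; beyond the scatter), is expected. Compound 4 is estimated at 1500 nM, within 400 nM to 6000 nM.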

Compound 4, half-maximal inhibitory concentration: 330 nM
For compound 4 the middle estimate is 4.5-fold (0.66 log units) above the measured one; the whole stated range lies above it.
By their numbers in this assay, from the lowest: compounds 1 and 4 (each within the scatter of the next); then compound 3; then compound 2.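

In this assay, this pair differs in one place only, and the step is large: (piperidin-1-yl)methyl in place of pyrrolidin-1-yl gives a 14-fold lower number from compound 2 to compound 4 (1.13 log units; beyond the scatter) with the rest of the structure unchanged. The earlier compounds shown here differ in several places and could not show that this end of the chain alone can shift the number so far. Nothing measured here accounts for the step. The change lengthens the chain and enlarges the ring together, and the compounds shown do not separate the two. A 3-(pyrrolidin-1-yl)propyl or 2-(piperidin-1-yl)ethyl group would tell them apart.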